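The source may hold more compounds than are shown below. What is called first, only, known or untested is meant among the compounds shown, and "the series" means these compounds.

In a functional assay on A549 cells (Homo sapiens) for cytotoxicity, read by MTT assay, with a stated time of 72 h (on this read-out lower numbers stand for stronger inhibition and higher numbers for weaker inhibition), three compounds have been measured. Compound 1 (`COc1cccc(/C=C2\CCC/C(=C\c3ccccc3Br)C2=O)c1OC`) gives > 20000 nM, which is a limit of the assay and not a number. Compound 2 (`COc1cccc(/C=C2\CCC/C(=C\c3cccc(O)c3)C2=O)c1OC`) gives > 20000 nM, which is also a limit. Among the compounds with values here, compound 3 (`COc1ccc(/C=C2\CCC/C(=C\c3cccc(Cl)c3)C2=O)cc1OC`) gives 11000 nM, the only true number in the set. The rest of the data amount to the limit of > 20000 nM in this assay, at which 2 of the 3 values shown sit.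

Compound 4 (`COc1ccc(/C=C2\CCC/C(=C\c3ccc(Br)cc3)C2=O)cc1OC`) differs from compound 3 in one place: 4-bromophenyl in place of 3-chlorophenyl on a double-bonded chain carbon bound to a double-bonded ring carbon. The change is 4-bromophenyl in place of 3-chlorophenyl on a double-bonded chain carbon bound to a double-bonded ring carbon. Within the data shown here, the only measured step at such a place is a step that the two limits leave unreadable from compound 1 to compound 2, so it offers no size to carry over. The expectation therefore rests on compound 3 at 11000 nM, and no shift beyond the scatter is expected in this assay, in either direction. The estimated change is a 1.1-fold higher number from compound 3 to compound 4 (0.04 log units; within the scatter). For compound 4 the expected value is 12000 nM, with an estimated range of 5000 nM to 25000 nM.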

Compound 4, half-maximal inhibitory concentration: 16000 nM
Beside the measured number, compound 4's estimate is 1.3-fold (0.12 log units) below it; measured number inside the range.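

In this assay, within the data shown here, 4-bromophenyl in place of 3-chlorophenyl on a double-bonded chain carbon bound to a double-bonded ring carbon comes to a 1.5-fold higher number from compound 3 to compound 4 (0.16 log units; within the scatter), the first step at this place with a readable size, as the earlier step cannot be read. On the shared core of compound 3 and compound 4, this place therefore tolerates the exchange of one halogen-bearing phenyl for another with no change beyond the scatter. This single readable step stands against a set in which the other values are a limit and not a number: the limit of > 20000 nM in this assay, at which 2 of the 4 values shown sit.

As far as these compounds go, the exchange alters both the halogen and its ring position, so the effect of each alone stays open. Also open, from the compounds shown here alone, is how the number would respond to an amine or a carboxylic acid on this phenyl ring.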